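Three Limits and an Untested Carbamoylphenyl Analogue

The compounds below may be only part of what the source reports. "The series", "measured", "known", "first", "only" and "open" are said of these compounds alone.

All three measured compounds were examined in a functional assay on HL-60 cells (Homo sapiens), read by calcium flux; on this read-out higher numbers stand for an effect only at larger amounts of compound and lower numbers for an effect already at smaller amounts.

Compound 1 `CCc1cc(Cc2cccc(OC)c2)c(=O)n(CC(=O)Nc2ccc(I)cc2)n1`: > 50000 nM
Compound 2 `Cc1cc(Cc2cccc(Br)c2)c(=O)n(CC(=O)Nc2ccc(Br)cc2)n1`: > 50000 nM
Compound 3 `Cc1cc(Cc2ccoc2)c(=O)n(CC(=O)Nc2ccc(Br)cc2)n1`: > 50000 nM

Each of these values is a limit of the assay and not a number. Compound 1 is reported only as a limit. Compound 2 is reported only as a limit. Compound 3 is reported only as a limit. Among the measured compounds shown here, the single step between compounds differing in one place, a step that the two limits leave unreadable from compound 2 to compound 3, runs between two limits and has no readable size. Compound 3 therefore stands at the limit of > 50000 nM in this assay, at which 3 of the 3 values shown sit, with nothing in the numbers to set it apart from the other two.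

Compound 4 `Cc1cc(Cc2ccc(C(N)=O)cc2)c(=O)n(CC(=O)Nc2ccc(Br)cc2)n1` differs from compound 3 by 4-carbamoylphenyl in place of furan-3-yl on a saturated chain carbon bound to an aromatic carbon. No measured step bears on this change, and the one step shown gives no size to lean on. Compound 4 is accordingly expected at 60000 nM, within 12000 nM to 300000 nM, most probably again as a limit. The step that the limit leaves unreadable from compound 3 to compound 4 is thus estimated as none beyond the scatter.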

Compound 4, half-maximal effective concentration: > 50000 nM
Compound 4 ended at the assay's limit; the forecaster's own chance of this, stated with the estimate: 80%; the middle value is on the limit's open side.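

In this assay compound 4 gives > 50000 nM, which is a limit of the assay and not a number. Its steps from compound 2 and compound 3 therefore cannot be read. The compounds shown leave open how large any of these changes is, and whether any change to the shared core gives a measurable effect.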